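A few compounds are considered here, and "the series" means these few. Any claim that something is new, unique, unknown or untested is made for them only; others in the source may bear on it.

Measured so far:
compound 1 `N#CC1=C(N)Oc2c(c3nc4ccccc4nc3c3ccccc23)C12C(=O)N(Cc1cnnn1-c1cccc(Cl)c1)c1ccccc12` — in an ADME assay on HUVEC cells (Homo sapiens) for antiproliferative activity, read by MTT assay, with a stated time of 48 h (a higher number here means a weaker inhibitor, a lower number a stronger inhibitor), compound 1 gives > 50000 nM, which is a limit of the assay and not a number.
compound 2 `Cc1cccc(-n2nncc2CN2C(=O)C3(C(C#N)=C(N)Oc4c(N)cc5nc6ccccc6nc5c43)c3ccccc32)c1` — in this assay compound 2 gives > 50000 nM, again a limit of the assay and not a number.

Compound 2 therefore stands only at a limit in this assay; no number is known for it. Going by the values given here, the same holds for the one further value shown, as the limit of > 50000 nM in this assay, at which 2 of the 2 values shown sit, records, so both measured compounds sit at the same limit and no step between them can be sized. Among the compounds with values here, no pair of measured compounds that differ in one place is available.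

Compound 3 `N#CC1=C(N)Oc2c(N)cc3nc4ccccc4nc3c2C12C(=O)N(Cc1cnnn1-c1ccc(F)cc1)c1ccccc12` differs from compound 2 by 4-fluorophenyl in place of 3-methylphenyl on an aromatic nitrogen. Nothing measured speaks to the size of this change. With both shown values at the limit, the step from compound 2 to compound 3 is expected to be none beyond the scatter, a number no higher from compound 2 to compound 3 (the limit leaves the size open), and compound 3 is expected most likely to return a limit as well. For compound 3 the estimate in this assay is 50000 nM, within a range from 20000 nM to 120000 nM.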

Compound 3, half-maximal inhibitory concentration: > 50000 nM
Compound 3 was reported as a limit (the forecaster's own chance of this, stated with the estimate: 85%); the middle value lies on the limit itself.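

In this assay compound 3 gives > 50000 nM as a limit of the assay and not a number. Going by these compounds alone, no step between compound 2 and compound 3 can be read: the limit of > 50000 nM in this assay, at which 3 of the 3 values shown sit. The compounds shown leave open how far compound 1, compound 2 and compound 3 each lie from that limit, and whether 4-fluorophenyl in place of 3-methylphenyl alters the read-out at all.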